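Para-methoxy on the aryl ring of a chlorinated pyran

The source may report more compounds than this note shows. Statements on the series, on what has been measured and on what is new or still open speak of the compounds shown alone.

Compound 1 `CC(C)C[C@H]1C[C@@H](Cl)C[C@@H](C2CCCCC2)O1`: 73000 nM
Compound 2 `CC(C)C[C@H]1C[C@@H](Cl)C[C@@H](c2ccccc2)O1`: 72000 nM

Both compounds were tested in a functional assay on A2780 cells (Homo sapiens) for antiproliferative activity; on this read-out lower numbers stand for higher toxicity in this test and higher numbers for lower toxicity in this test. Compound 1 gives 73000 nM in this assay, and compound 2 gives 72000 nM. The two numbers cannot be told apart: the gap between them lies within the scatter of repeated measurements, so exchanging the saturated ring of compound 1 for the aromatic ring of compound 2 leaves the read-out unchanged on the evidence shown.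

Compound 3 `COc1ccc([C@@H]2C[C@H](Cl)C[C@H](CC(C)C)O2)cc1` has not yet been measured. It differs from compound 2 in one place: methoxy in place of hydrogen on an aromatic carbon. Going by the values given here, no measured pair shows what such a change does to this read-out. With nothing to point either way, the expectation is a step from compound 2 to compound 3 of a 1.2-fold lower number from compound 2 to compound 3 (0.08 log units; within the scatter), which is not beyond the scatter. Compound 3 is therefore expected to give 60000 nM in this assay, within a range from 20000 nM to 150000 nM.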

Compound 3, concentration lethal to 50% of the cells: 95000 nM
The estimate for compound 3 lay 1.6-fold (0.20 log units) below the measured number; low and high end bracket the measured number.
By their numbers in this assay, from the lowest: compounds 2, 1 and 3 (each within the scatter of the next).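

Putting methoxy in place of hydrogen on the aromatic ring, para to a large group, gives a 1.3-fold higher number from compound 2 to compound 3 (0.12 log units; within the scatter) in this assay. The earlier pair changed only the ring itself, whereas this step shows that adding a group to that ring also leaves the read-out indistinguishable on the evidence shown. Nothing available explains this outcome.

From the compounds shown here alone, it remains open whether a different group at this same place, such as an amine or a carboxylic acid, would shift the number beyond the scatter. Also open, going by these compounds, is what would follow from changing the shared core elsewhere, for instance a hydroxyl group in place of the chlorine or a longer chain in place of the branched one.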